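A few compounds are considered here, and "the series" means these few. Any claim that something is new, unique, unknown or untested is made for them only; others in the source may bear on it.

Measured so far:
compound 1 `CCOc1ccc(C2C(C3CC3)C(=O)N2c2cc(OC)c(OC)c(OC)c2)cc1` gives 201 nM
compound 2 `C=CC1C(=O)N(c2cc(OC)c(OC)c(OC)c2)C1c1ccc(SC)cc1` gives 61 nM

In a functional assay on HL-60 cells (Homo sapiens) for inhibition, read by resazurin assay, with a stated time of 72 h (on this read-out higher numbers stand for weaker inhibition and lower numbers for stronger inhibition), compound 2 stands lowest of the two numbers, and its gap to compound 1 lies beyond the scatter. Compound 3 `COc1cc(N2C(=O)C(C3CC3)C2c2ccc(SC)cc2)cc(OC)c1OC` is not yet measured. The change cyclopropyl in place of vinyl on a saturated ring carbon puts cyclopropyl in place of vinyl on a saturated ring carbon. Within the data shown here, no step between measured compounds shows this change on its own. Compound 1, which also bears cyclopropyl, stands at 201 nM in this assay and so a small move toward a higher number is expected. An estimated 1.3-fold higher number from compound 2 to compound 3 (0.12 log units; within the scatter) would stay within the scatter. Compound 3 is estimated at 80 nM with 28 nM to 230 nM as the expected range.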

Compound 3, half-maximal inhibitory concentration: 279 nM
The estimate for compound 3 lay 3.5-fold (0.54 log units) below the measured number; measured number outside the range, above it.
By their numbers in this assay, from the lowest: compound 2; then compounds 1 and 3 (each within the scatter of the next).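

In this assay, among these compounds, cyclopropyl in place of vinyl on a saturated ring carbon gives the first direct reading at this position: a 4.6-fold higher number from compound 2 to compound 3 (0.66 log units; beyond the scatter), a step beyond the scatter. With cyclopropyl held constant, methylsulfanyl in place of ethoxy on an aromatic carbon gives a 1.4-fold higher number from compound 1 to compound 3 (0.14 log units; within the scatter), a step within the scatter, so this pair shows no separation. Nothing at hand accounts for the step away from vinyl.

Open, as far as these compounds go, is whether ethyl or a longer chain on this ring carbon would stay close to compound 2. Also open, from the compounds shown here alone, is whether the vinyl step holds with ethoxy on the aromatic carbon.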